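The source may hold more compounds than are shown below. What is called first, only, known or untested is meant among the compounds shown, and "the series" means these compounds.

Of the compounds shown here, two have been tested for tolerance by human lung fibroblast cells, and a third is about to be. Compound 1, `COc1ccc(CN2c3ccccc3C(=O)N(Cc3ccccc3)S2(=O)=O)cc1`, gives a measured value of 61000 nM in a functional assay on MRC5 cells (Homo sapiens); a higher number here means that more compound is tolerated, a lower number that less compound is tolerated. Compound 2, `O=C1c2ccccc2N(Cc2ccccc2-c2ccccc2)S(=O)(=O)N1Cc1ccccc1`, reaches only a limit of the method, > 55000 nM, in this assay, so no exact number is known for it. Going by the values given here, that limit, described as the limit of > 55000 nM in this assay, at which 1 of the 2 values shown sits, is where one of the two values so far sits, and the other value, that of compound 1, lies close to it.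

Compound 3, `O=C1c2ccccc2N(Cc2ccccc2Cl)S(=O)(=O)N1Cc1ccccc1`, differs from compound 2 in one place: chloro in place of phenyl on an aromatic carbon. Among the compounds with values here, nothing measured here tells how such an exchange shifts cell tolerance, and no step between measured compounds is available as a guide. With both known values clustered near the limit, the expectation is a step from compound 2 to compound 3 of no size beyond the usual scatter, a step that the limit leaves unreadable from compound 2 to compound 3. Compound 3 is therefore estimated at 60000 nM, with a likely range from 25000 nM to 150000 nM.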

Compound 3, half-maximal cytotoxic concentration: 60000 nM
For compound 3 middle estimate and measured number coincide at the digits printed, and the stated range covers the measured number.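

At the saturated chain carbon bound to a sulfonamide nitrogen in a ring, 2-chlorophenyl in place of 4-methoxyphenyl gives a 1.0-fold lower number from compound 1 to compound 3 (0.01 log units; within the scatter). Going by these compounds alone, this is the first step that can be read, and it shows that this assay does not tell these two groups apart at this position. The effect of chloro in place of phenyl on the aromatic carbon cannot be read, because compound 2 has no exact number, only a limit: the limit of > 55000 nM in this assay, at which 1 of the 3 values shown sits.

The compounds shown leave open whether an amine or a carboxylic acid in place of chloro on that aromatic carbon would give a number clearly different from that of compound 3. Within the data shown here, also open is whether any change at this position, or any change to the shared core, can produce a step beyond the scatter in this assay, since the one readable step gives no sign of how far the number can move.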